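The compounds below may be only part of what the source reports. "The series", "measured", "known", "first", "only" and "open" are said of these compounds alone.

Compound 1 `CCCCCCCN1CCC(C(=O)Nc2cc(Cl)c(N)cc2OC)CC1` in a functional assay on the whole organism for antagonist activity, with Mus musculus as the target (on this read-out lower numbers stand for an effect already at smaller amounts and higher numbers for an effect only at larger amounts of compound), gives > 10 mg/kg, a limit of the assay and not a number.
Compound 2 `COc1cc(N)c(Cl)cc1NC(=O)C1CCN(Cc2ccccc2Cl)CC1` in this assay gives > 4 mg/kg, again a limit and not a number.
Compound 3 `COc1cc(N)c(Cl)cc1NC(=O)C1CCN(CC2CCCCCC2)CC1` in this assay gives > 10 mg/kg, once more a limit and not a number.

All three compounds share one core and differ only in the group carried on a saturated chain carbon bound to an amine nitrogen in a ring. Compound 2 stands only as a limit; the two other values shown are limits as well the limit of > 10 mg/kg in this assay, at which 2 of the 3 values shown sit (the limit of > 4 mg/kg in this assay, at which 1 of the 3 values shown sits), so none of the three is placed against the others.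

Compound 4 `COc1cc(N)c(Cl)cc1NC(=O)C1CCN(Cc2ccc(O)cc2)CC1` is not yet measured. It differs from compound 2 as follows: 4-hydroxyphenyl in place of 2-chlorophenyl on a saturated chain carbon bound to an amine nitrogen in a ring.

The measured steps that touch the same place are a step that the two limits leave unreadable from compound 1 to compound 2, a step that the two limits leave unreadable from compound 1 to compound 3 and a step that the two limits leave unreadable from compound 2 to compound 3. Each of them joins two limits, so none gives a size or a direction. Within the data shown here, no measured step therefore tells how the change to a 4-hydroxyphenyl group should move the dose, and the expectation for compound 4 rests on the three limits alone.

Compound 4 is expected to sit near the same region as compound 2, at an estimated 10 mg/kg, with a range from 2 mg/kg to 40 mg/kg. The step this estimate means is a step that the limit leaves unreadable from compound 2 to compound 4, and most likely the assay again reports only a limit.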

Compound 4, dose for half-maximal effect: > 8 mg/kg
Compound 4: only a limit was reported; the forecaster's own chance of this, stated with the estimate: 75%; the middle value lies beyond the limit too.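

Compound 4 is reported only as a limit, as are compound 1, compound 2 and compound 3, so none of the steps joining compound 4 to these three can be read for size or direction. The compounds shown leave open whether any of these four groups on the shared core gives a real dose value in this assay, and how the four would rank.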